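The source may hold more compounds than are shown below. What is called first, only, known or untested is meant among the compounds shown, and "the series" means these compounds.

- compound 1 `Cc1ccc(S(=O)(=O)Oc2ccccc2/C=C(\C#N)C(=O)Nc2nnc(C)s2)cc1`: 35%
- compound 2 `N#C/C(=C\c1ccccc1OS(=O)(=O)c1ccccc1[N+](=O)[O-])C(=O)Nc1nnc(Cc2cccc3ccccc23)s1`: "not toxic" (no number reported)

In an ADME assay on HEK-293T cells (Homo sapiens) for inhibition, read by CCK-8 assay, with a stated time of 48 h, tested at 20 uM (a higher number here means more inhibition of growth at the concentration tested, a lower number less inhibition of growth), compound 1 gives 35%. Among the measured compounds shown here, this is the only actual number available, so it cannot yet be called high or low against other compounds. Compound 2 is reported only as "not toxic" (no number reported), a verdict rather than a measurement, and it differs from compound 1 in more than one place.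

The next compound to consider is compound 3 `Cc1ccc(S(=O)(=O)Oc2ccccc2/C=C(\C#N)C(=O)Nc2nnc(Cc3ccccc3)s2)cc1`. It keeps the core of compound 1 and changes in one place: phenyl in place of hydrogen on a saturated chain carbon bound to an aromatic carbon. Cut one bond further out, this reads as methyl to benzyl, or 5-methyl-1,3,4-thiadiazol-2-yl to 5-benzyl-1,3,4-thiadiazol-2-yl.

For the measured compounds named here, no measured pair of compounds isolates this change, so its effect in this assay remains unknown. The only weak hint of direction comes from compound 2, with its report of "not toxic" (no number reported), and this points slightly downward. The expected result is a small fall, with an estimated a number 10 percentage points lower from compound 1 to compound 3 (within the scatter). The estimate for compound 3 is 25%, with an expected range from 5% to 50%.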

Compound 3, percent growth inhibition at one concentration: 15%
The estimate for compound 3 lay 10 percentage points above the measured number; measured number inside the range.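

In this assay, phenyl in place of hydrogen on a saturated chain carbon bound to an aromatic carbon, which reads as methyl to benzyl, gives a number 20 percentage points lower from compound 1 to compound 3 (beyond the scatter). This single-place comparison shows that the group carried at this position of the shared core can change the reading, and that in this pair the benzyl group goes with less inhibition of growth at the concentration tested than the methyl group. Nothing at hand explains why the number falls, so the step stands as an observation and not as an explanation.

The compounds shown leave open whether the fall follows from the aromatic ring itself or simply from extending the group beyond methyl, a question that an ethyl group or a longer saturated chain at the same place would address. They also leave open how a benzyl ring carrying an amine or a carboxylic acid would read, and whether this one step would hold on a different version of the core.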